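The source may hold more compounds than are shown below. What is called first, only, known or untested is meant among the compounds shown, and "the series" means these compounds.

In a functional assay on PC-3 cells (Homo sapiens) for cytotoxicity, with a stated time of 48 h (a lower number here means a stronger inhibitor, a higher number a weaker inhibitor), compound 1 `COc1cc(OC)c(C(=O)/C=C/c2ccccc2)c(OC)c1` gives 5100 nM, compound 2 `COc1cc(OC)c(C(=O)/C=C/c2ccc(Cl)cc2)c(OC)c1` gives 5800 nM and compound 3 `COc1cc(OC)c(C(=O)/C=C/c2ccc(F)cc2)c(OC)c1` gives 5500 nM, so compound 3 sits level with the other two within the scatter. Compound 4 `COc1cc(OC)c(C(=O)/C=C/c2ccc([N+](=O)[O-])cc2)c(OC)c1` differs from compound 3 in one place: nitro in place of fluoro on an aromatic carbon. The closest evidence comes from swaps on an aromatic carbon: a 1.1-fold higher number from compound 1 to compound 2 (0.06 log units; within the scatter), a 1.1-fold higher number from compound 1 to compound 3 (0.03 log units; within the scatter) and a 1.1-fold lower number from compound 2 to compound 3 (0.02 log units; within the scatter). All three stay within the scatter, although none of them involves a nitro group, so this evidence is only indirect. No step beyond the scatter is therefore expected, in either direction, and the expected change is a 1.1-fold lower number from compound 3 to compound 4 (0.06 log units; within the scatter). The estimated value for compound 4 is 4800 nM, with an expected range from 2000 nM to 11000 nM.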

Compound 4, half-maximal inhibitory concentration: 2500 nM
Compound 4: middle estimate off by 1.9-fold (0.28 log units), on the high side; measured number inside the range.
By their numbers in this assay, from the lowest: compound 4; then compounds 1, 3 and 2 (each within the scatter of the next).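

Within the data shown here, at this position, para to a large group, nitro is the first group to move the number beyond the scatter: a 2.2-fold lower number from compound 3 to compound 4 (0.34 log units; beyond the scatter) and a 2.3-fold lower number from compound 2 to compound 4 (0.37 log units; beyond the scatter) and a 2.0-fold lower number from compound 1 to compound 4 (0.31 log units; beyond the scatter). Hydrogen, chloro and fluoro could not be told apart here, so the flat picture from the earlier compounds does not hold for every group, although the step is modest. Nothing available here accounts for this step.

As far as these compounds go, whether an amine or a carboxylic acid at this position would shift the number, and in which direction, remains open.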